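Swapping an Aromatic Ring for a Saturated One

The compounds below may be only part of what the source reports. "The series", "measured", "known", "first", "only" and "open" are said of these compounds alone.

Compound 1 `Nc1ccc(Nc2c(C(=O)NCc3ccc(F)cc3)nc(Br)c3cccnc23)cc1`: in a functional assay on LNCaP cells (Homo sapiens) for cytotoxicity, read by MTT assay, with a stated time of 72 h (on this read-out higher numbers stand for weaker inhibition and lower numbers for stronger inhibition), compound 1 gives 7000 nM.
Compound 2 `NCCCNc1c(C(=O)NCc2ccc(F)cc2)ncc2cccnc12`: in this assay compound 2 reaches only a limit, > 10000 nM.

Among the measured compounds shown here, compound 1 holds the only full number in this set, and it is a weak one. The value of compound 2 is a limit, (the limit of > 10000 nM in this assay, at which 1 of the 2 values shown sits), so the distance between the two compounds cannot be read off. Compound 3 `N[C@H]1CC[C@H](Nc2c(C(=O)NCc3ccc(F)cc3)nc(Br)c3cccnc23)CC1` differs from compound 1 in one place: 4-aminocyclohexyl in place of 4-aminophenyl on a nitrogen on an aromatic ring. For the measured compounds named here, no pair of measured compounds shows what this kind of change does, so there is no measured step to lean on. In the absence of such guidance, the step of a 1.1-fold higher number from compound 1 to compound 3 (0.06 log units; within the scatter) is expected to be none beyond the usual scatter, with a fair chance that only a limit is reported. For compound 3 the estimate in this assay is therefore 8000 nM, within a range of 2500 nM to 25000 nM.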

Compound 3, half-maximal inhibitory concentration: 5000 nM
The estimate for compound 3 lay 1.6-fold (0.20 log units) above the measured number, within the range that was stated.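

In this assay, replacing the aromatic ring with a saturated one at this place gives a 1.4-fold lower number from compound 1 to compound 3 (0.15 log units; within the scatter). For this pair, then, an aromatic ring on this nitrogen is not needed to keep the activity at this modest level, provided the amine-bearing six-membered carbon ring stays in place. The data shown offer no measurement that would explain why the two rings behave alike.

Going by these compounds, it remains open whether another group on this nitrogen, such as a piperidine ring, a morpholine ring or a chain ending in a carboxylic acid, would shift the number beyond the scatter. Also open, on these data alone, is how the other arrangement of the two stereocentres in the 4-aminocyclohexyl group would compare with compound 3.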